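Swapping the fused bicyclic ring: compound 3 to compound 4

The source may report more compounds than this note shows. Statements on the series, on what has been measured and on what is new or still open speak of the compounds shown alone.

Three compounds have been measured in an assay on isolated protein for binding affinity to somatostatin receptor type 1 (Homo sapiens); a higher number here means weaker binding, a lower number tighter binding:
Compound 1 `COC(=O)c1cc(C[C@@H](C)CN2C[C@@H]3CCCC[C@@H]3[C@H](C(=O)N3CCN(c4ccc([N+](=O)[O-])cc4)CC3)C2)cc(C(=O)OC)c1` gives 437 nM.
Compound 2 `C[C@@H](Cc1ccc2ocnc2c1)CN1C[C@@H]2CCCC[C@@H]2[C@H](C(=O)N2CCN(c3ccc(F)c(F)c3)CC2)C1` gives 1620 nM.
Compound 3 `Cc1cn2cc(C[C@H](C)CN3C[C@@H]4CCCC[C@@H]4[C@H](C(=O)N4CCN(c5ccc(F)c(F)c5)CC4)C3)ccc2n1` gives 39.8 nM.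

All three share the same core; they differ in the aromatic group carried on the saturated side chain. Compound 3 stands at the lowest number of the three in this assay, so it binds most tightly: compound 1 sits at a higher number and compound 2 higher still, both gaps beyond the scatter.

Compound 4 `C[C@@H](Cc1ccc2nccnc2c1)CN1C[C@@H]2CCCC[C@@H]2[C@H](C(=O)N2CCN(c3ccc(F)c(F)c3)CC2)C1` is the next variation on this side chain. The change is a group of 10 heavy atoms (8 carbon, 2 nitrogen; one six-membered aromatic ring of carbon only, one six-membered aromatic ring with 2 hetero atoms) in place of a group of 10 heavy atoms (8 carbon, 2 nitrogen; one five-membered aromatic ring with 2 hetero atoms, one six-membered aromatic ring with 1 hetero atom), on a saturated chain carbon, three bonds along the chain from an amine nitrogen in a ring. The group that leaves and the group that enters are counted alike in atoms and acceptors; what differs is the shape of the fused rings.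

Among the compounds with values here, only one measured step speaks to this position: a 41-fold lower number from compound 2 to compound 3 (1.61 log units; beyond the scatter). That step shows the fused ring at this position can move the number a great deal, but it gives no direction for a quinoxalin-6-yl group, which is not otherwise represented.

The expectation for compound 4 is therefore a step of a 3.8-fold higher number from compound 3 to compound 4 (0.58 log units; beyond the scatter), a loss of some binding relative to compound 3, with wide uncertainty. Compound 4 is estimated at 150 nM, between 30 nM and 800 nM.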

Compound 4, dissociation constant: 2630 nM
The estimate for compound 4 lay 18-fold (1.24 log units) below the measured number, and the stated range ends below it.
By their numbers in this assay, from the lowest: compound 3; then compound 1; then compounds 2 and 4 (each within the scatter of the next).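

In this assay, this change gives a 66-fold higher number from compound 3 to compound 4 (1.82 log units; beyond the scatter), even though the group that leaves and quinoxalin-6-yl have the same counts of heavy atoms, nitrogens and hydrogen-bond acceptors, so at this position those counts alone do not settle the number. The other new comparison, with quinoxalin-6-yl in place of 1,3-benzoxazol-5-yl, gives a 1.6-fold higher number from compound 2 to compound 4 (0.21 log units; within the scatter), so these two groups, despite their different rings and hetero atoms, cannot be told apart in this assay. Compound 3 therefore stands apart from both compound 2 and compound 4, which shows that the tight binding in this set belongs to its particular pair of rings, with a five-membered aromatic ring carrying 2 hetero atoms, and not to any two-ring aromatic group on this saturated chain carbon.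

The compounds shown offer no measurement that explains why this ring arrangement matters so much. As far as these compounds go, it also remains open whether a simpler single ring at this position, such as a phenyl or a pyridine, would sit nearer compound 3 or nearer compound 2 and compound 4.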